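Swapping a chloro for an ethyl carbamate on an arylpiperazine

This account rests on a few compounds, and the source may have more. Where it says the series, first, only, none or still open, it means among the compounds named here.

Measured so far:
- compound 1 `O=C(NCCCCN1CCN(c2cccc(Cl)c2)CC1)c1ccc2ccccc2c1`: 50.2 nM
- compound 2 `Cc1cccc(N2CCN(CCCCNC(=O)c3ccc4ccccc4c3)CC2)c1C`: 230 nM

In an assay on isolated protein for displacement of a labelled ligand from Alpha-1A adrenergic receptor (Homo sapiens) (a higher number here means a weaker inhibitor, a lower number a stronger inhibitor), compound 1 gives 50.2 nM, the lowest of the two numbers in hand, so it is the stronger binder of the pair. Its nearest neighbour is compound 2, whose 230 nM sits a 4.6-fold higher number from compound 1 to compound 2 (0.66 log units; beyond the scatter) away.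

Compound 3 `CCOC(=O)Nc1cccc(N2CCN(CCCCNC(=O)c3ccc4ccccc4c3)CC2)c1` has not yet been measured. It differs from compound 1 by (ethoxycarbonyl)amino in place of chloro on an aromatic carbon, the new group sitting meta to a large group on the same aromatic ring that carries the piperazine nitrogen.

Among the compounds with values here, only one measured step speaks to this change, and only loosely: the step of a 4.6-fold higher number from compound 1 to compound 2 (0.66 log units; beyond the scatter) shows that altering the substituents on this aromatic ring can shift binding by a modest amount, though that step swapped in methyl groups rather than a carbamate. Within the data shown here, with no closer precedent, a modest loss is expected, on the order of a 2.2-fold higher number from compound 1 to compound 3 (0.34 log units; beyond the scatter).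

Compound 3 is therefore estimated at 110 nM in this assay, with a likely range from 30 nM to 400 nM.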

Compound 3, inhibition constant: 1030 nM
Estimate against measurement, compound 3: 9.4-fold (0.97 log units) below; the whole stated range lies below it.
By their numbers in this assay, from the lowest: compound 1; then compound 2; then compound 3.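

In this assay, this place on the aromatic ring does not accept every replacement for chloro: putting (ethoxycarbonyl)amino there gives a 21-fold higher number from compound 1 to compound 3 (1.31 log units; beyond the scatter), a step classed as large. Within the data shown here, the only earlier change on this ring, a 4.6-fold higher number from compound 1 to compound 2 (0.66 log units; beyond the scatter), was classed as modest, so substituents on this ring can affect binding more strongly than that step alone showed. The new group brings six heavy atoms in place of one, along with a hydrogen-bond donor and hydrogen-bond acceptors, but no evidence is available to show which of these differences, if any, lies behind the higher number.

The compounds shown leave open whether the loss follows from the whole group or from one part of it, such as the carbonyl or the ethyl end; a plain amine or a methyl carbamate on the same aromatic carbon would help separate those parts. They also leave open whether another small atom, such as fluorine or bromine, would give a number close to that of compound 1.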